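Swapping the ring for an amide at the meta position

The compounds below may be only part of what the source reports. "The series", "measured", "known", "first", "only" and "open" are said of these compounds alone.

In an assay on isolated protein for inhibition of adenosine deaminase (Bos taurus), with a stated time of 5 min (on this read-out higher numbers stand for weaker inhibition and lower numbers for stronger inhibition), compound 1 `C[C@H](O)[C@@H](CCc1cccc(F)c1)n1cnc2c(N)ncnc21` gives 1.6 nM. Compound 2 `C[C@H](O)[C@@H](CCc1cccc(-c2cnccn2)c1)n1cnc2c(N)ncnc21` carries pyrazin-2-yl where compound 1 carries fluoro; in this assay compound 2 gives 1.9 nM. The step of a 1.2-fold higher number from compound 1 to compound 2 (0.07 log units; within the scatter) shows that these two numbers lie within the scatter of each other, so compound 2 stands level with compound 1 and neither can be called the stronger.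

Compound 3 `CNC(=O)c1cccc(CC[C@H]([C@H](C)O)n2cnc3c(N)ncnc32)c1` differs from compound 2 at the same point: methylcarbamoyl in place of pyrazin-2-yl on an aromatic carbon. Among the compounds with values here, only one measured step touches this position, a 1.2-fold higher number from compound 1 to compound 2 (0.07 log units; within the scatter), and it stayed within the scatter, suggesting that this aromatic carbon tolerates different groups. Within the data shown here, no measured compound carries an amide there, so the expectation is tentative. For compound 3 a step of a 1.3-fold higher number from compound 2 to compound 3 (0.12 log units; within the scatter) is expected in this assay, small and most likely within the scatter. Compound 3 is therefore estimated at 2.5 nM, with a range from 0.8 nM to 8 nM.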

Compound 3, inhibition constant: 2.7 nM
For compound 3 the middle estimate is 1.1-fold (0.03 log units) below the measured one; measured number inside the range.
By their numbers in this assay, from the lowest: compounds 1, 2 and 3 (each within the scatter of the next).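

In this assay, replacing the ring with methylcarbamoyl gives a 1.4-fold higher number from compound 2 to compound 3 (0.15 log units; within the scatter), and the same group compared with fluoro gives a 1.7-fold higher number from compound 1 to compound 3 (0.23 log units; within the scatter), with both steps within the scatter. The earlier pair showed only that a fluoro and an aromatic ring read alike on this aromatic carbon; compound 3 adds a group with no ring, a double bond outside aromatic rings and a hydrogen-bond donor, and its number still stands level with both. Nothing available here explains why such different groups read alike.

The compounds shown leave open whether an amine or a carboxylic acid on this aromatic carbon would also stand level with them. From the compounds shown here alone, it also remains open whether dimethylcarbamoyl, which has no amide hydrogen, or a longer chain on the amide nitrogen would do the same.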